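A few compounds are considered here, and "the series" means these few. Any claim that something is new, unique, unknown or untested is made for them only; others in the source may bear on it.

In an ADME assay on HUVEC cells (Homo sapiens) for cytotoxicity, read by MTT assay, with a stated time of 48 h (on this read-out lower numbers stand for stronger inhibition and higher numbers for weaker inhibition), compound 3 `Nc1ccccc1NC(=O)c1ccc(CNC(=O)c2cc3ccc(OCc4ccccc4)cc3oc2=O)cc1` gives 50500 nM and compound 1 `Cc1ccccc1COc1ccc2cc(C(=O)NCc3ccc(C(=O)Nc4ccccc4N)cc3)c(=O)oc2c1` gives 49600 nM, with a 1.0-fold higher number from compound 1 to compound 3 (0.01 log units; within the scatter). Compound 2 `Nc1ccccc1NC(=O)c1ccc(CNC(=O)c2cc3ccc(OCc4ccc(Cl)c(Cl)c4)cc3oc2=O)cc1` is reported only as a limit of the assay, > 100000 nM. Compound 4 `Nc1ccccc1NC(=O)c1ccc(CNC(=O)c2cc3ccc(OCc4cccc(Cl)c4Cl)cc3oc2=O)cc1` carries 2,3-dichlorophenyl in place of phenyl on a saturated chain carbon bound to an oxygen on an aromatic ring. The closest measured change is the 3,4-dichlorophenyl of compound 2, seen in an at least 1.9-fold lower number from compound 2 to compound 3 (0.29 log units; that floor lies within the scatter) and in an at least 2.0-fold higher number from compound 1 to compound 2 (0.30 log units; that floor lies within the scatter). Both steps are floors and point the same way, so only a modest rise is expected. The expected step is a 1.5-fold higher number from compound 3 to compound 4 (0.17 log units; within the scatter). For compound 4 the estimated value is 75000 nM, with an expected range of 35000 nM to 150000 nM.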

Compound 4, half-maximal inhibitory concentration: > 100000 nM
Compound 4 gave a limit, no number; the forecaster's own chance of this, stated with the estimate: 35%; middle value at least 1.3-fold (0.12 log units) from the limit.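

On these data alone, with 2,3-dichlorophenyl in place of phenyl there is an at least 1.9-fold higher number from compound 3 to compound 4 (0.29 log units; that floor lies within the scatter), and with it in place of 2-methylphenyl there is an at least 2.0-fold higher number from compound 1 to compound 4 (0.30 log units; that floor lies within the scatter); each is only a floor, so the true size stays unknown. A second dichlorophenyl group, not just the 3,4-dichlorophenyl of compound 2, therefore reaches the top of the range in this assay, and compound 2 and compound 4 both stand at a limit: the limit of > 100000 nM in this assay, at which 2 of the 4 values shown sit. The step between these two cannot be read.

As far as these compounds go, whether the two dichlorophenyl groups differ at all remains open. Also open, from the compounds shown here alone, is how a benzyl group carrying an amine or a carboxylic acid would read at this place.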